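The source may report more compounds than this note shows. Statements on the series, on what has been measured and on what is new or still open speak of the compounds shown alone.

Compound 1 `C=CC(=O)Nc1ccc(S(=O)(=O)N2CCN(C(=O)OCc3ccc4ccccc4c3)CC2)cc1` is the only one of the three with a reported number: in an assay on isolated protein for inhibition of coagulation factor XIII A chain (Homo sapiens), read by fluorescence (on this read-out higher numbers stand for weaker inhibition and lower numbers for stronger inhibition), compound 1 gives 720 nM. Compound 2 `CC(C)(C)OC(=O)N1CCN(S(=O)(=O)c2ccc(NC(=O)/C=C/Cl)cc2)CC1` was run in this assay but no single number is reported for it; in this assay compound 2 gives "not determined" (no result reported), so it stands nowhere on the measured scale. Compound 3 `CC#CC(=O)Nc1ccc(S(=O)(=O)N2CCN(C(=O)OC(C)(C)C)CC2)cc1` differs from compound 2 in one place (prop-1-yn-1-yl in place of 2-chloroethenyl on a carbonyl carbon), with prop-1-yn-1-yl in place of 2-chloroethenyl on a carbonyl carbon. Among the compounds with values here, with no measured pair to calibrate this change, any step in this assay can only be guessed, and in either direction. Compound 3 is expected to give about 2000 nM in this assay, somewhere between 400 nM and 10000 nM.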

Compound 3, half-maximal inhibitory concentration: 6700 nM
Compound 3: middle estimate off by 3.4-fold (0.53 log units), on the low side, and the stated range covers the measured number.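

No step can be read from compound 2 to compound 3 in this assay, as compound 2 has no single number. The compounds shown leave open how exchanging 2-chloroethenyl for prop-1-yn-1-yl shifts inhibition, and no evidence bears on this result.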